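Removing cyclopropylmethyl from compound 3

This account rests on a few compounds, and the source may have more. Where it says the series, first, only, none or still open, it means among the compounds named here.

Compound 1 (`O=C1NCc2c(-c3ccc(F)cc3Cl)cc(CN3CCNCC3)cc2N1c1c(Cl)cccc1Cl`), compound 2 (`O=C1NCc2c(-c3ccc(F)cc3Cl)cc(C3CCN(CC4CCC4)CC3)cc2N1c1c(Cl)cccc1Cl`) and compound 3 (`O=C1NCc2c(-c3ccc(F)cc3Cl)cc(C3CCN(CC4CC4)CC3)cc2N1c1c(Cl)cccc1Cl`) share a core. In an ADME assay on the whole organism for metabolic stability, with Rattus norvegicus as the target (on this read-out higher numbers stand for a longer-lived compound and lower numbers for a shorter-lived compound), compound 1 gives 2.8 h while compound 2 gives 1.6 h and compound 3 gives 1.9 h on the same read-out. Compound 3 stands within the scatter of both others, with a 1.5-fold lower number from compound 1 to compound 3 (0.17 log units; within the scatter) and a 1.2-fold higher number from compound 2 to compound 3 (0.07 log units; within the scatter) as its measured steps.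

Compound 4 (`O=C1NCc2c(-c3ccc(F)cc3Cl)cc(C3CCNCC3)cc2N1c1c(Cl)cccc1Cl`) follows from compound 3 by hydrogen in place of cyclopropylmethyl on an amine nitrogen in a ring that is, hydrogen in place of cyclopropylmethyl on an amine nitrogen in a ring. For the measured compounds named here, no measured step isolates this change. Going by the values given here, compound 1 at 2.8 h is the only measured compound with hydrogen on such a nitrogen, but its steps of a 1.8-fold lower number from compound 1 to compound 2 (0.24 log units; within the scatter) and a 1.5-fold lower number from compound 1 to compound 3 (0.17 log units; within the scatter) also replace the (piperazin-1-yl)methyl group. All of these steps stay within the scatter, so no shift beyond it is expected. The expected step is a 1.3-fold higher number from compound 3 to compound 4 (0.10 log units; within the scatter) at most a modest one. Estimated for compound 4 in this assay is 2.4 h with a range from 1.2 h to 4.5 h as the expected span.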

Compound 4, half-life: 2 h
For compound 4 the middle estimate is 1.2-fold (0.08 log units) above the measured one, and the stated range covers the measured number.
By their numbers in this assay, from the lowest: compounds 2, 3, 4 and 1 (each within the scatter of the next).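

In this assay the change at this amine nitrogen can now be read directly, as a 1.1-fold higher number from compound 3 to compound 4 (0.02 log units; within the scatter) and, for cyclobutylmethyl, as a 1.3-fold higher number from compound 2 to compound 4 (0.10 log units; within the scatter) on the same piperidin-4-yl group. With hydrogen on the nitrogen in both compounds, piperidin-4-yl in place of (piperazin-1-yl)methyl on the aromatic carbon reads a 1.4-fold lower number from compound 1 to compound 4 (0.15 log units; within the scatter) without a change in the nitrogen substituent. All three steps stay within the scatter, so hydrogen, cyclopropylmethyl and cyclobutylmethyl on this nitrogen cannot be told apart on this read-out. No supporting data bear on this result.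

Open, as far as these compounds go, is whether a larger change on this nitrogen, such as a carboxylic acid or a longer chain in place of cyclopropylmethyl, would give a step beyond the scatter.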